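The source may hold more compounds than are shown below. What is called first, only, known or untested is meant among the compounds shown, and "the series" means these compounds.

Measured so far in a functional assay on HOS cells (Homo sapiens) for antiproliferative activity, read by sulforhodamine B assay; on this read-out higher numbers stand for weaker inhibition of growth and lower numbers for stronger inhibition of growth:

Compound 1 `CC(=O)O[C@@H]1[C@@H](OCc2ccccc2)[C@H](OCc2ccccc2)[C@@H](COCc2ccccc2)O[C@H]1C`; compound 1 gives 8800 nM.
Compound 2 `CCC[C@@H]1O[C@H](COCc2ccccc2)[C@@H](OCc2ccccc2)[C@H](OCc2ccccc2)[C@@H]1O`; compound 2 gives only a limit, > 50000 nM.
Compound 3 `CCC[C@@H]1O[C@H](COCc2ccc3ccccc3c2)[C@@H](OCc2ccc3ccccc3c2)[C@H](OCc2ccc3ccccc3c2)[C@H]1O`; compound 3 gives only a limit, > 50000 nM.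

Among the measured compounds shown here, compound 1 holds the only actual number in this assay; the other two values are limits rather than numbers, and the notable feature of the set is the limit of > 50000 nM in this assay, at which 2 of the 3 values shown sit. For the measured compounds named here, compounds 2 and 3 differ from compound 1 in more than one place, so no single step between measured compounds can be read off. Their values show only that both sit at the limit while compound 1 does not.

Compound 4 `C=CC[C@@H]1O[C@H](COCc2ccccc2)[C@@H](OCc2ccccc2)[C@H](OCc2ccccc2)[C@H]1OC(C)=O` is not yet measured. It differs from compound 1 by vinyl in place of hydrogen on a saturated chain carbon bound to a saturated ring carbon. Going by the values given here, no measured pair isolates a change of this kind, so its size is open and rests on the general picture that growth inhibition is weak throughout.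

The step from compound 1 to compound 4 is expected to be small, with a slight lean toward weaker inhibition, a 1.5-fold higher number from compound 1 to compound 4 (0.17 log units; within the scatter). For compound 4 the estimated value in this assay is 13000 nM, with a range of 4000 nM to 45000 nM. The upper end is kept wide because compound 2 reaches only the limit > 50000 nM in this assay.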

Compound 4, concentration for 50% growth inhibition: 11000 nM
Compound 4: the middle estimate sits 1.2-fold (0.07 log units) above what was measured; low and high end bracket the measured number.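

In this assay, vinyl in place of hydrogen on a saturated chain carbon bound to a saturated ring carbon gives a 1.3-fold higher number from compound 1 to compound 4 (0.10 log units; within the scatter). Among the compounds shown here, this is the first step that can be read at a single place, and it shows that the same difference, read as methyl to allyl, leaves growth inhibition in this assay unchanged within the usual scatter, with compound 4 returning a number rather than a limit. Compound 2 and compound 3 remain at a limit, which is not a number: the limit of > 50000 nM in this assay, at which 2 of the 4 values shown sit.

Whether this position accepts groups other than allyl stays open, as a longer chain, a primary amine or a carboxylic acid on the same saturated chain carbon has no value among the compounds shown. Going by these compounds, the steps linking compound 2 and compound 3 to compound 1 or compound 4 cannot be read, and the contribution of the acetyl ester on the shared core also stays open.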